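Swapping the bicyclic ring on a triaryl acrylic acid core

A few compounds are considered here, and "the series" means these few. Any claim that something is new, unique, unknown or untested is made for them only; others in the source may bear on it.

Compound 1 `CC/C(=C(/c1ccc(/C=C/C(=O)O)cc1)c1ccn2nccc2c1)c1ccccc1` — > 500 nM
Compound 2 `CC/C(=C(/c1ccc(/C=C/C(=O)O)cc1)c1ccc2nccn2c1)c1ccccc1` — 170 nM
Compound 3 `CC/C(=C(/c1ccc(/C=C/C(=O)O)cc1)c1ccn2nncc2c1)c1ccccc1` — > 500 nM

Among the compounds with values here, in a functional assay on MCF7 cells (Homo sapiens) for antiproliferative activity, read by CellTiter-Glo, with a stated time of 5 days (on this read-out higher numbers stand for weaker inhibition and lower numbers for stronger inhibition), compound 2 gives 170 nM, the only number among the three values shown. For compound 1 the result is a limit, > 500 nM. For compound 3 the result is also a limit, > 500 nM. Compound 4 `CC/C(=C(/c1ccc(/C=C/C(=O)O)cc1)c1ccc2scnc2c1)c1ccccc1` differs from compound 2 by a group of 9 heavy atoms (7 carbon, 1 nitrogen, 1 sulfur; one five-membered aromatic ring with 2 hetero atoms, one six-membered aromatic ring of carbon only) in place of a group of 9 heavy atoms (7 carbon, 2 nitrogen; one five-membered aromatic ring with 2 hetero atoms, one six-membered aromatic ring with 1 hetero atom), on a double-bonded chain carbon bound to an aromatic carbon and a double-bonded chain carbon. Within the data shown here, two measured steps bear on this: an at least 2.9-fold lower number from compound 1 to compound 2 (0.46 log units; beyond the scatter) and an at least 2.9-fold higher number from compound 2 to compound 3 (0.46 log units; beyond the scatter), so both exchanges of the ring system of compound 2 read as at least modest increases, a fact set by the limit of > 500 nM in this assay, at which 2 of the 3 values shown sit. A modest increase is therefore expected for compound 4, namely a 2.1-fold higher number from compound 2 to compound 4 (0.31 log units; beyond the scatter). Compound 4 is estimated at 350 nM, within 120 nM to 900 nM.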

Compound 4, half-maximal inhibitory concentration: 90 nM
Compound 4: middle estimate off by 3.9-fold (0.59 log units), on the high side; measured number outside the range, below it.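

At this place, on a double-bonded chain carbon bound to an aromatic carbon and a double-bonded chain carbon, 1,3-benzothiazol-5-yl brings sulfur and a six-membered aromatic ring of carbon only, yet in this assay it reads level with the ring system of compound 2, with a 1.9-fold lower number from compound 2 to compound 4 (0.28 log units; within the scatter). The same group stands clearly apart from two other ring systems, with an at least 5.5-fold lower number from compound 3 to compound 4 (0.74 log units; beyond the scatter) and with an at least 5.5-fold lower number from compound 1 to compound 4 (0.74 log units; beyond the scatter). These two steps are minimum sizes, as compound 1 and compound 3 each give a limit and not a number: the limit of > 500 nM in this assay, at which 2 of the 4 values shown sit.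

Sulfur and the carbon-only six-membered ring enter together in compound 4, and the compounds shown do not separate them. On these data alone, how oxygen in place of the sulfur, or an amine on the ring system, would read also remains open.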